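A Fluoro Substituent Added to the Ring of Compound 2

A few compounds are considered here, and "the series" means these few. Any claim that something is new, unique, unknown or untested is made for them only; others in the source may bear on it.

Compound 1, `N/C(=N\NC(=S)N1CCCC1)c1ccc(F)cn1`: 85.4%
Compound 2, `N/C(=N\NC(=S)N1CCSCC1)c1ccccn1`: 88.7%

Both measured compounds were tested in a functional assay on HeLa cells (Homo sapiens) for cytotoxicity, read by MTT assay, with a stated time of 72 h, tested at 100 uM; a lower number here means less inhibition of growth, a higher number more inhibition of growth at the concentration tested. Compound 1 `N/C(=N\NC(=S)N1CCCC1)c1ccc(F)cn1` gives 85.4%, and compound 2 `N/C(=N\NC(=S)N1CCSCC1)c1ccccn1` gives 88.7%; the two numbers lie within the scatter of each other, so neither can be set above the other. Compound 2 therefore stands together with compound 1, with nothing in the data to separate them.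

Compound 3 `N/C(=N\NC(=S)N1CCSCC1)c1ccc(F)cn1` differs from compound 2 in one place: fluoro in place of hydrogen on an aromatic carbon. Going by the values given here, no measured pair shows this change on its own, but compound 1 carries the same fluoro on a different core, and compound 1 gives 85.4% in this assay, close to compound 2. The step of a number 1.7 percentage points lower from compound 2 to compound 3 (within the scatter) is estimated to lie within the scatter, in no clear direction. Compound 3 is expected to give 87%, in the range 77% to 95%.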

Compound 3, percent growth inhibition at one concentration: 88.1%
Estimate against measurement, compound 3: 1.1 percentage points below, and the stated range covers the measured number.
By their numbers in this assay, from the lowest: compounds 1, 3 and 2 (each within the scatter of the next).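

In this assay, the direct pair shows that fluoro in place of hydrogen on an aromatic carbon, two atoms from the ring nitrogen and para to a large group, amounts to a number 0.6 percentage points lower from compound 2 to compound 3 (within the scatter) on the thiomorpholin-4-yl compounds. With fluoro present in both compounds, the pair differing at the thiocarbonyl carbon adds that thiomorpholin-4-yl in place of pyrrolidin-1-yl gives a number 2.7 percentage points higher from compound 1 to compound 3 (within the scatter) in this read-out, so neither single change separates the compounds at the concentration tested. No supporting data bear on these results.

The compounds shown leave open whether an amine or a methoxy group at this same position would give a step beyond the scatter. They also leave open whether compound 2 and compound 3 would differ at lower concentrations.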